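A few compounds are considered here, and "the series" means these few. Any claim that something is new, unique, unknown or untested is made for them only; others in the source may bear on it.

Compound 3 `Cc1ccc2[nH]c(=O)c(CN(Cc3ccc(O)cc3)Cc3ccc(C(C)(C)C)cc3)cc2c1` is the only one of the three measured compounds to give an actual number: in a toxicity assay on MDCK cells (Canis lupus familiaris) for cytotoxicity, read by crystal violet staining, with a stated time of 48 h (on this read-out higher numbers stand for lower toxicity in this test and lower numbers for higher toxicity in this test), compound 3 gives 4900 nM. Compound 1 `CCc1ccc2[nH]c(=O)c(CN(CCCO)Cc3ccc(C(C)(C)C)cc3)cc2c1` reaches only the assay limit of > 10000 nM in this assay. Compound 2 `CCc1ccc2[nH]c(=O)c(CN(Cc3ccc(OCOC)cc3)Cc3ccc(C(C)(C)C)cc3)cc2c1` likewise stops at the assay limit of > 10000 nM in this assay. Compound 4 `CCc1ccc2[nH]c(=O)c(CN(Cc3ccc(O)cc3)Cc3ccc(C(C)(C)C)cc3)cc2c1` has not been measured; it differs from compound 3 by methyl in place of hydrogen on a saturated chain carbon bound to an aromatic carbon, which, seen one bond further out, reads methyl to ethyl on the shared core. Going by the values given here, no measured step concerns this change: the only recorded step, a step that the two limits leave unreadable from compound 1 to compound 2, alters the group on the amine nitrogen rather than the core, and its size cannot be read because both of its ends rest on (the limit of > 10000 nM in this assay, at which 2 of the 3 values shown sit). Compounds 1 and 2 do carry the ethyl group that compound 4 would carry, yet their other groups differ from those of compound 3, so they do not set the size of this step. A small change of this kind is expected to shift the read-out little, so the step from compound 3 to compound 4 is estimated at a 1.4-fold higher number from compound 3 to compound 4 (0.15 log units; within the scatter). Compound 4 is therefore expected to show about 7000 nM, within 3000 nM to 20000 nM.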

Compound 4, half-maximal cytotoxic concentration: > 10000 nM
Compound 4 was reported as a limit; the forecaster's own chance of this, stated with the estimate: 40%; middle value at least 1.4-fold (0.15 log units) from the limit.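

Going by these compounds alone, the pair gives the first reading at this position: in this assay, going from methyl to ethyl on the shared core comes with an at least 2.0-fold higher number from compound 3 to compound 4 (0.30 log units; that floor lies within the scatter). This step is only a floor, as compound 4 gives a limit and not a number, and that floor lies within the usual scatter, so it does not show a real change in the read-out. The steps from compound 1 to compound 4 and from compound 2 to compound 4 cannot be read, and most of the compounds shown now rest on the same limit: the limit of > 10000 nM in this assay, at which 3 of the 4 values shown sit.

On these data alone, the true size of the step from methyl to ethyl therefore stays open. Also open, as far as these compounds go, is how a longer chain such as propyl, or a chain ending in an amine, would read at this place on the shared core.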